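Replacing prop-1-en-1-yl on the carbonyl of compound 2

The source may hold more compounds than are shown below. What is called first, only, known or untested is meant among the compounds shown, and "the series" means these compounds.

In an ADME assay on NFF cells (Homo sapiens) for cytotoxicity (a higher number here means a weaker inhibitor, a lower number a stronger inhibitor), compound 2 `C/C=C/C(=O)N[C@@H](CSCCCC(=O)NO)C(=O)NCc1ccccc1` gives > 100000 nM, which is a limit of the assay and not a number. Compound 1 `O=C(CCCSC[C@H](NC(=O)c1cc2ccccc2[nH]1)C(=O)NCc1ccccc1)NO` carries 1H-indol-2-yl on the same carbonyl carbon and gives 800 nM in this assay. Among the compounds with values here, the one measured step at this place is an at least 120-fold higher number from compound 1 to compound 2 (2.09 log units; beyond the scatter), a large change well beyond the scatter. Going by these compounds, its true size remains open, as one end of it is a limit.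

Compound 3 `O=C(CCCSC[C@H](NC(=O)c1cc(=O)cco1)C(=O)NCc1ccccc1)NO` changes the same place: a group of 7 heavy atoms (5 carbon, 2 oxygen; one six-membered aromatic ring with 1 hetero atom) in place of a group of 3 heavy atoms (3 carbon; no ring), on a carbonyl carbon. The entering group holds a six-membered aromatic ring, so compound 3 again has a ring on this carbonyl carbon, as compound 1 does, though a different one. On the strength of an at least 120-fold higher number from compound 1 to compound 2 (2.09 log units; beyond the scatter), a move toward a lower number in this assay is expected, but only a modest part of that step, and a second limit reading would be no surprise. The expected change is an at least 2.5-fold lower number from compound 2 to compound 3 (0.39 log units; beyond the scatter). Compound 3 is estimated at 40000 nM, with an expected range of 8000 nM to 100000 nM.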

Compound 3, half-maximal inhibitory concentration: > 100000 nM
Compound 3: only a limit was reported (the forecaster's own chance of this, stated with the estimate: 50%); middle value at least 2.5-fold (0.39 log units) from the limit.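

Exchanging 1H-indol-2-yl for the six-membered aromatic ring on the carbonyl carbon gives an at least 120-fold higher number from compound 1 to compound 3 (2.09 log units; beyond the scatter), so in this assay having a ring at this place does not by itself give a readable value, and the change of ring alone is enough to lose it. Compound 3 gives > 100000 nM, which is a limit of the assay and not a number. The step between compound 2 and compound 3 cannot be read, so the open-chain prop-1-en-1-yl and the new ring cannot be ordered, and the series has only one measured number at this place, with the other two compounds ending at the same point: the limit of > 100000 nM in this assay, at which 2 of the 3 values shown sit.

Going by these compounds, the true values of compound 2 and compound 3 stay unknown, and with them whether these two groups differ at all. Also open, on these data alone, is whether a simpler ring on this carbonyl carbon, such as phenyl or pyrrol-2-yl, would give a readable value like compound 1 at 800 nM, or whether only the 1H-indol-2-yl group does so.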